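Compound 3 to compound 4: methyl to chloro

The source may report more compounds than this note shows. Statements on the series, on what has been measured and on what is new or still open speak of the compounds shown alone.

Compound 1 `Nc1cc(-c2ccc(Cl)cc2)nn1-c1cccc(Cl)c1`: > 100000 nM (a limit)
Compound 2 `CN(C)/C=N/c1c(C=O)c(-c2ccc(Cl)cc2)nn1-c1cccc(Cl)c1`: 7400 nM
Compound 3 `Cc1ccc(-c2nn(-c3cccc(Cl)c3)c(N)c2C=O)cc1`: > 100000 nM (a limit)

All three results come from a functional assay on NPC-TW01 cells (Homo sapiens) for inhibition, read by MTT assay, with a stated time of 72 h; on this read-out higher numbers stand for weaker inhibition of growth and lower numbers for stronger inhibition of growth. Compound 3 reads > 100000 nM, which is a limit and not a number. The set shows (the limit of > 100000 nM in this assay, at which 2 of the 3 values shown sit).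

Compound 4 `Nc1c(C=O)c(-c2ccc(Cl)cc2)nn1-c1cccc(Cl)c1` differs from compound 3 by chloro in place of methyl on an aromatic carbon, para to a large group: chloro in place of methyl on an aromatic carbon. Among the measured compounds shown here, no measured pair isolates this change. No step beyond the scatter is expected in this assay, and no direction can be assigned. The estimated change is a number no higher from compound 3 to compound 4 (the limit leaves the size open). For compound 4 the expected value is 100000 nM, with an estimated range from 30000 nM to 200000 nM.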

Compound 4, concentration for 50% growth inhibition: > 100000 nM
Compound 4 ended at the assay's limit (the forecaster's own chance of this, stated with the estimate: 75%); the middle value sits exactly at the limit.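

In this assay compound 4 reads > 100000 nM, which is a limit and not a number. Taking the larger group off the nitrogen of compound 2 gives an at least 13-fold higher number from compound 2 to compound 4 (1.13 log units; beyond the scatter), the first readable step in the series, so with the formyl and 4-chlorophenyl kept, growth inhibition is seen only with that group present. The steps to compound 4 from compound 1 and from compound 3 join two limits and cannot be read.

As far as these compounds go, whether 4-methylphenyl and 4-chlorophenyl differ at all stays open, as most of the set sits at one limit: the limit of > 100000 nM in this assay, at which 3 of the 4 values shown sit. Also open is whether an acetyl or a single methyl on that nitrogen would keep any of the growth inhibition of compound 2.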